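A few compounds are considered here, and "the series" means these few. Any claim that something is new, unique, unknown or untested is made for them only; others in the source may bear on it.

Measured so far in an ADME assay on Akata cells (Homo sapiens) for cytotoxicity, with a stated time of 7 days; a higher number here means that more compound is tolerated, a lower number that less compound is tolerated:
Compound 1 `CN(C)c1nc(N)nc2c1ncn2/C=C1/CC1(CO)CO`: > 24000 nM
Compound 2 `CCCCCCCCSc1nc(N)nc2c1ncn2/C=C1/CC1(CO)CO`: > 20000 nM

Compound 2 stands at > 20000 nM, and this is a limit of the assay rather than a number. Compound 1 stands at > 24000 nM, which is also a limit. For the measured compounds named here, the only measured step is a step that the two limits leave unreadable from compound 1 to compound 2.

Compound 3 `Nc1nc(NC2CCCCC2)c2ncn(/C=C3/CC3(CO)CO)c2n1` has cyclohexylamino in place of the octylsulfanyl of compound 2 on an aromatic carbon: cyclohexylamino in place of octylsulfanyl on an aromatic carbon.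

Going by the values given here, the one measured step gives no size to carry over. Neither compound on that step reached a number, so no step beyond the usual scatter is expected in this assay, in either direction. The estimated step is a step that the limit leaves unreadable from compound 2 to compound 3. For compound 3 the expected value is 22000 nM, within an estimated range of 9000 nM to 45000 nM.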

Compound 3, half-maximal cytotoxic concentration: > 24000 nM
Compound 3: no number, only a limit; the forecaster's own chance of this, stated with the estimate: 75%; at least 1.0-fold (0.03 log units) between middle value and limit.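

Compound 3, like compound 1 and compound 2, gives only a limit and not a number, so no step among these three compounds can be read: the limit of > 24000 nM in this assay, at which 2 of the 3 values shown sit.

Going by these compounds, the concentration at which any of the three harms these cells remains open, as does how far apart they lie.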